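A few compounds are considered here, and "the series" means these few. Any claim that something is new, unique, unknown or untested is made for them only; others in the source may bear on it.

Three compounds that share one core and differ only in the substituted phenyl group on a nitrogen have been measured. In a functional assay on HCT-116 cells (Homo sapiens) for antiproliferative activity, read by radiometric assay, with a stated time of 72 h (on this read-out lower numbers stand for stronger inhibition and higher numbers for weaker inhibition), compound 1 `Cc1cc(F)ccc1Nc1ncnc2cc(NC(=O)CCCCCCC(=O)NO)sc12` gives 2640 nM, compound 2 `O=C(CCCCCCC(=O)Nc1cc2ncnc(Nc3ccc(Cl)cc3F)c2s1)NO` gives 1790 nM and compound 3 `CCc1cccc(Nc2ncnc3cc(NC(=O)CCCCCCC(=O)NO)sc23)c1` gives 1440 nM. Compound 3 therefore cannot be told apart from the other two, since all three values lie within the usual scatter of one another.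

Compound 4 `N#Cc1cccc(Nc2ncnc3cc(NC(=O)CCCCCCC(=O)NO)sc23)c1` has not yet been measured. It differs from compound 3 by a single change, cyano in place of ethyl on an aromatic carbon, meta to a large group (cyano in place of ethyl on an aromatic carbon). Going by the values given here, no measured compound carries this cyano group, so the evidence is indirect and comes from other swaps of the same phenyl group. These are a 1.5-fold lower number from compound 1 to compound 2 (0.17 log units; within the scatter), a 1.8-fold lower number from compound 1 to compound 3 (0.26 log units; within the scatter) and a 1.2-fold lower number from compound 2 to compound 3 (0.09 log units; within the scatter), each within the scatter.

Because a 1.2-fold lower number from compound 2 to compound 3 (0.09 log units; within the scatter) and the other two swaps stayed this small, no step beyond the scatter is expected in this assay, and the data indicate no firm direction. The estimate amounts to a 1.3-fold higher number from compound 3 to compound 4 (0.10 log units; within the scatter), an expected step that stays inside the scatter. For compound 4 the expected value is 1800 nM, with an estimated range from 700 nM to 4500 nM.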

Compound 4, half-maximal inhibitory concentration: 2090 nM
Compound 4: middle estimate off by 1.2-fold (0.06 log units), on the low side, within the range that was stated.
By their numbers in this assay, from the lowest: compounds 3, 2, 4 and 1 (each within the scatter of the next).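

This is the first compound shown with a nitrile on the phenyl group, which brings a triple bond and a hydrogen-bond acceptor that ethyl lacks. In this assay, placing cyano in the position of ethyl, on an aromatic carbon meta to a large group, gives a 1.5-fold higher number from compound 3 to compound 4 (0.16 log units; within the scatter). Set against the two other phenyl groups on the same nitrogen, compound 4 shows a 1.2-fold higher number from compound 2 to compound 4 (0.07 log units; within the scatter) and a 1.3-fold lower number from compound 1 to compound 4 (0.10 log units; within the scatter), so across these four compounds neither ethyl nor cyano can be told apart from the other phenyl groups on this read-out, and no measurement shown explains why these groups read alike.

On these data alone, whether any group on this phenyl ring can move the number beyond the scatter remains open, and an amine, a carboxylic acid or a longer chain such as propyl in the same position would test this. Also open is how cyano would read at another carbon of the ring, as the compounds shown carry it at this one place only.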